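Methyl to methoxy on two related cores: working notes

The source may report more compounds than this note shows. Statements on the series, on what has been measured and on what is new or still open speak of the compounds shown alone.

Measured in a functional assay on MCF7 cells (Homo sapiens) for inhibition, read by MTT assay, with a stated time of 48 h; on this read-out lower numbers stand for stronger inhibition and higher numbers for weaker inhibition:
- compound 1, `Cc1ccc(-n2cc(NC(=O)c3cccc(NS(=O)(=O)c4ccccc4)c3)cn2)cc1`, 1690 nM
- compound 2, `COc1ccc(-n2cc(NC(=O)c3cccc(NS(=O)(=O)c4ccccc4)c3)cn2)cc1`, 18700 nM
- compound 3, `Cc1ccc(-n2cc(NC(=O)c3ccc(NS(=O)(=O)c4ccccc4)cc3)cn2)cc1`, 10900 nM

Compound 1 and compound 3 have the same atoms joined differently; the difference between the two cores is not broken down here. Compound 3 stands second highest of the three numbers, and against compound 2 its number is within the scatter, so no order between those two is claimed.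

From compound 1 to compound 2 the change is methoxy in place of methyl on an aromatic carbon, and it gave an 11-fold higher number from compound 1 to compound 2 (1.04 log units; beyond the scatter).

Compound 4, `COc1ccc(-n2cc(NC(=O)c3ccc(NS(=O)(=O)c4ccccc4)cc3)cn2)cc1`, is not yet measured. It differs from compound 3 by methoxy in place of methyl on an aromatic carbon, the same change as from compound 1 to compound 2, on the core of compound 3 instead.

Expected for compound 4 is a 6.4-fold higher number from compound 3 to compound 4 (0.81 log units; beyond the scatter), on the single precedent an 11-fold higher number from compound 1 to compound 2 (1.04 log units; beyond the scatter); since only one such pair exists, the size is uncertain and the number may approach the upper range of this assay.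

Compound 4 is estimated at 70000 nM, with a likely range from 20000 nM to 200000 nM.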

Compound 4, half-maximal inhibitory concentration: 25600 nM
Compound 4: the middle estimate sits 2.7-fold (0.44 log units) above what was measured, within the range that was stated.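

On the second core, methoxy in place of methyl again moved the number in the same direction in this assay, with a 2.3-fold higher number from compound 3 to compound 4 (0.37 log units; beyond the scatter). The direction of the change therefore held on both cores shown, but its size did not carry over: the same change on two cores in this assay, an 11-fold higher number (1.04 log units; beyond the scatter) from compound 1 to compound 2 and a 2.3-fold higher number (0.37 log units; beyond the scatter) from compound 3 to compound 4, 4.7-fold (0.67 log units) apart, beyond the scatter of two such steps

The size of the step on one core is thus a poor guide to its size on the other, and these two pairs show neither what sets the size nor whether the same direction would hold on a further core.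

Among the compounds shown, only the 4-methylphenyl and 4-methoxyphenyl groups appear at this place, so it remains open how an amine, a carboxylic acid or a longer chain in place of the methyl would read on either core. Also open, going by these compounds, is whether the two cores would keep the same gap between steps for any change other than methoxy in place of methyl.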